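The compounds below may be only part of what the source reports. "The series", "measured", "known", "first", "only" and "open" are said of these compounds alone.

Series notes. Of the compounds shown here, two of the shared core have been measured in an ADME assay on cells (Mus musculus, strain BALB/c) for cytotoxicity, read by MTT assay, with a stated time of 24 h; on this read-out lower numbers stand for higher toxicity in this test and higher numbers for lower toxicity in this test: compound 1 `COc1cc(-c2nnc(SCc3ccccc3[N+](=O)[O-])o2)ccc1O` and compound 2 `COc1cc(-c2nnc(SCc3ccc(F)cc3F)o2)ccc1O`. Compound 1 gives 331000 nM; compound 2 gives 520000 nM. Compound 1 stands at the lower of the two numbers, and the gap to compound 2 lies within the scatter, so no order between them can be read.

Compound 3 `COc1cc(-c2nnc(SCc3ccccc3C)o2)ccc1O` is not yet measured in this assay. It differs from compound 1 in one place: methyl in place of nitro on an aromatic carbon, on an aromatic carbon ortho to a large group. Going by the values given here, both measured numbers sit close together, and no step between measured compounds is available, so the change from compound 1 to compound 3 is expected to give none beyond the scatter, a 1.2-fold higher number from compound 1 to compound 3 (0.08 log units; within the scatter). Compound 3 is estimated at 400000 nM, within 180000 nM to 900000 nM.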

Compound 3, half-maximal cytotoxic concentration: 592000 nM
Compound 3: middle estimate off by 1.5-fold (0.17 log units), on the low side; the measured number falls inside the stated range.
By their numbers in this assay, from the lowest: compounds 1, 2 and 3 (each within the scatter of the next).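

In this assay methyl in place of nitro on an aromatic carbon ortho to a large group gives a 1.8-fold higher number from compound 1 to compound 3 (0.25 log units; within the scatter) and so leaves the read-out within the scatter. 2-methylphenyl in place of 2,4-difluorophenyl on a saturated chain carbon bound to a sulfur gives a 1.1-fold higher number from compound 2 to compound 3 (0.06 log units; within the scatter) and likewise shows no readable change. No measurement at hand offers a reason for either step. Going by these compounds, whether an amine or a carboxylic acid on this aromatic carbon would move the number beyond the scatter stays open. On these data alone, a longer chain in place of the saturated chain carbon bound to a sulfur also stays open.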